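The compounds below may be only part of what the source reports. "The series", "measured", "known", "first", "only" and "open" are said of these compounds alone.

Working notes on the series.

Within the data shown here, compound 3 `Cc1cccc(C)c1NC(=O)/C=C/C(=O)N1C/C(=C\c2ccc([N+](=O)[O-])cc2)C(=O)/C(=C/c2ccc([N+](=O)[O-])cc2)C1` gives 230 nM in a functional assay on CCRF-CEM cells (Homo sapiens) for cytotoxicity (on this read-out lower numbers stand for stronger inhibition and higher numbers for weaker inhibition), the lowest of the three numbers so far; compound 1 `O=C(/C=C/C(=O)N1C/C(=C\c2ccccc2)C(=O)/C(=C/c2ccccc2)C1)Nc1ccc(Cl)c(Cl)c1` sits within the scatter of it at 350 nM, while compound 2 `O=C(/C=C/C(=O)N1C/C(=C\c2ccccc2)C(=O)/C(=C/c2ccccc2)C1)Nc1ccccc1` gives 1100 nM, a gap beyond the scatter. Among the measured compounds shown here, the one step measured, a 3.1-fold higher number from compound 1 to compound 2 (0.50 log units; beyond the scatter), changes the aryl on the amide-type nitrogen and shows that this position can move the number by a modest amount.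

Compound 4 `CC(=O)c1ccc(NC(=O)/C=C/C(=O)N2C/C(=C\c3ccc([N+](=O)[O-])cc3)C(=O)/C(=C/c3ccc([N+](=O)[O-])cc3)C2)cc1` is not yet measured. It differs from compound 3 by 4-acetylphenyl in place of 2,6-dimethylphenyl on an amide-type nitrogen. For the measured compounds named here, no measured pair compares 4-acetylphenyl with 2,6-dimethylphenyl at this position, so the direction of the change cannot be read from the data; the step from compound 1 to compound 2 only suggests that the size should be modest. The estimate for compound 4 is therefore close to compound 3, expected as 350 nM with a range from 120 nM to 1000 nM, which corresponds to an expected step of a 1.5-fold higher number from compound 3 to compound 4 (0.18 log units; within the scatter).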

Compound 4, half-maximal inhibitory concentration: 360 nM
The estimate for compound 4 lay 1.0-fold (0.01 log units) below the measured number; the measured number falls inside the stated range.
By their numbers in this assay, from the lowest: compounds 3, 1 and 4 (each within the scatter of the next); then compound 2.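

The step of a 1.6-fold higher number from compound 3 to compound 4 (0.19 log units; within the scatter) shows that, in this assay, replacing 2,6-dimethylphenyl with 4-acetylphenyl on the amide-type nitrogen does not separate the two compounds. The earlier step at this nitrogen lay beyond the scatter, so a change of aryl here does not always shift the number by more than the scatter. An aryl group carrying a carbonyl, the one hydrogen-bond acceptor counted for 4-acetylphenyl, therefore fits this position without a readable change on the core of compound 3. Nothing at hand bears on why the two compounds read alike.

From the compounds shown here alone, it remains open whether a carboxylic acid or an amine on the aryl ring would behave the same way. A plain alkyl chain in place of the aryl on this nitrogen is also an open case.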